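The compounds below may be only part of what the source reports. "The series", "measured", "known", "first", "only" and "open" are said of these compounds alone.

Compound 1 `COc1ccc(-c2ccc(OCc3cc(C(=O)O)oc3C)cc2)cc1OC`, compound 2 `CC(=O)c1ccc(-c2ccc(OCc3cc(C(=O)O)oc3C)cc2)cc1` and compound 3 `CC(=O)c1ccc(-c2ccc(OCc3cc(C(=O)NS(=O)(=O)c4ccccc4)oc3C)cc2)cc1` share one core and differ either at the outer aromatic ring or at the carbonyl carbon of the acid. In an assay on cells for displacement of a labelled ligand from prostaglandin E2 receptor EP4 subtype (Homo sapiens), read by scintillation counting (on this read-out higher numbers stand for weaker inhibition and lower numbers for stronger inhibition), compound 1 gives 2800 nM, compound 2 gives 150 nM and compound 3 gives 20 nM. On these three numbers compound 2 stands second highest: its nearest neighbour is compound 3, reached by a 7.5-fold lower number from compound 2 to compound 3 (0.88 log units; beyond the scatter), while the values of compound 1 and compound 2 show that the methoxy-bearing compound 1 sits far above compound 2.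

Compound 4 `Cc1oc(C(=O)O)cc1COc1ccc(-c2ccc(OC(F)(F)F)cc2)cc1` is compound 2 with trifluoromethoxy in place of acetyl on an aromatic carbon. Among the measured compounds shown here, the only single-place step measured, a 7.5-fold lower number from compound 2 to compound 3 (0.88 log units; beyond the scatter), alters the carbonyl end and leaves the outer ring untouched, so it does not bear on this change. For the measured compounds named here, the pair compound 1 and compound 2 is the only comparison at that ring; it changes more than one place, and its two values show only that replacing the acetyl by methoxy substituents coincides with a much higher number. Going by the values given here, no measured step therefore maps onto trifluoromethoxy in place of acetyl. Accordingly the expected step for compound 4 is a 2.7-fold higher number from compound 2 to compound 4 (0.43 log units; beyond the scatter), leaning toward a somewhat higher number but with wide uncertainty. The estimate for compound 4 in this assay is 400 nM, with a range from 100 nM to 1500 nM.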

Compound 4, inhibition constant: 2400 nM
Estimate against measurement, compound 4: 6.0-fold (0.78 log units) below; measured number above the stated range.
By their numbers in this assay, from the lowest: compound 3; then compound 2; then compounds 4 and 1 (each within the scatter of the next).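

In this assay, the outer-ring position, an aromatic carbon para to a large group, proves sensitive to a single change: trifluoromethoxy in place of acetyl gives a 16-fold higher number from compound 2 to compound 4 (1.20 log units; beyond the scatter) and counts as a large step. Among the compounds shown here, this is the first step at this position in which nothing else differs, so the rise in the number can be tied to this one exchange, with the acid end and the rest of the shared core left as they are. The two groups have the same counts of hydrogen-bond donors and acceptors and neither carries a net charge, so those counts do not separate them, although acetyl has a double bond outside aromatic rings and trifluoromethoxy has none, and no available evidence explains the step.

The compounds shown do not tell whether the higher number comes from losing acetyl or from introducing trifluoromethoxy, a question that a nitrile, a primary amide or a propanoyl group at the same carbon could help to settle. They also leave open whether (phenylsulfonyl)amino in place of hydroxy, which gives a 7.5-fold lower number from compound 2 to compound 3 (0.88 log units; beyond the scatter) with acetyl on the outer ring, would act in the same way with trifluoromethoxy there.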